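Carbamate swap on the triazole-dithiocarbamate piperazine series

This account rests on a few compounds, and the source may have more. Where it says the series, first, only, none or still open, it means among the compounds named here.

Among the compounds with values here, compound 2 `COc1ccc(Cn2cc(CSC(=S)N3CCN(C(=O)OCc4ccccc4)CC3)nn2)cc1` gives 30500 nM in a functional assay on MCF7 cells (Homo sapiens) for inhibition, read by MTT assay, with a stated time of 72 h (on this read-out higher numbers stand for weaker inhibition and lower numbers for stronger inhibition), the lower of the two numbers measured so far; compound 1 `COc1ccc(-n2cc(CSC(=S)N3CCN(C(=O)OC(C)(C)C)CC3)nn2)cc1` gives 93100 nM in this assay. Compound 3 `COc1cc(Cn2cc(CSC(=S)N3CCN(C(=O)OCc4ccccc4)CC3)nn2)cc(OC)c1OC` reaches only the limit > 128000 nM, and this is the limit of the assay rather than a number (the limit of > 128000 nM in this assay, at which 1 of the 3 values shown sits). Within the data shown here, the one measured step, an at least 4.1-fold higher number from compound 2 to compound 3 (0.62 log units; beyond the scatter), concerns the group on the saturated chain carbon bound to the aromatic nitrogen and so does not touch the carbamate end.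

Compound 4 `COc1ccc(Cn2cc(CSC(=S)N3CCN(C(=O)OC(C)(C)C)CC3)nn2)cc1` differs from compound 2 by tert-butyl in place of benzyl on an oxygen next to a carbonyl group. Among the measured compounds shown here, no measured step covers this change; compound 1 carries the same tert-butyl carbamate but also a different group on the triazole, so its value and the value of compound 2 can only be set side by side. On that basis a higher number than for compound 2 is expected, with the step of a 2.0-fold higher number from compound 2 to compound 4 (0.29 log units; within the scatter) as the estimate. Compound 4 is expected at 60000 nM in this assay, in the range 25000 nM to 150000 nM.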

Compound 4, half-maximal inhibitory concentration: 4960 nM
Estimate against measurement, compound 4: 12-fold (1.08 log units) above, outside the stated range (below it).
By their numbers in this assay, from the lowest: compound 4; then compound 2; then compound 1. At a limit, above all of these: compound 3.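

Within the data shown here, the group on an oxygen next to a carbonyl group turns out to matter in this assay: tert-butyl in place of benzyl gives a 6.1-fold lower number from compound 2 to compound 4 (0.79 log units; beyond the scatter) and is the first measured change at this end of the series. With the tert-butyl carbamate held constant, 4-methoxybenzyl in place of 4-methoxyphenyl on an aromatic nitrogen gives a 19-fold lower number from compound 1 to compound 4 (1.27 log units; beyond the scatter) and is a large step, so the lowest number shown depends on the groups at both ends. Nothing measured here bears on the reason for either step.

Open, going by these compounds, is whether a free amine or an amide at the carbamate end would hold the value of compound 4. Also open, on these data alone, is whether 3,4,5-trimethoxyphenyl on the saturated chain carbon would behave the same way with tert-butyl on the carbamate oxygen as it does with benzyl.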